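Cytotoxicity notes on a quinoline-amine series, compound 3 to compound 4

The source may report more compounds than this note shows. Statements on the series, on what has been measured and on what is new or still open speak of the compounds shown alone.

Measured so far:
compound 1, `NC(=O)NCCNc1cc(N2CCc3ccccc3C2)nc2ccccc12`: 80000 nM
compound 2, `NCCNc1cc(N2CCCc3ccccc3C2)nc2cccc(Cl)c12`: 23000 nM
compound 3, `Cc1ccc2nc(N3CCCc4ccc(F)cc4C3)cc(NCC(C)N)c2c1`: 86000 nM

Three compounds have been run in an ADME assay on HEp-2 cells (Homo sapiens) for cytotoxicity, read by CCK-8 assay, with a stated time of 5 days; a lower number here means that less compound is tolerated, a higher number that more compound is tolerated. Compound 3 gives the highest number of the three, 86000 nM. Compound 1 sits within the scatter of compound 3, so no order between these two can be claimed. Compound 2 lies beyond the scatter below compound 3.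

Next to be measured is compound 4, `Cc1ccc2nc(N3CCCc4ccc(F)cc4C3)cc(NC3(CN)COC3)c2c1`. It differs from compound 3 in one place: 3-(aminomethyl)oxetan-3-yl in place of 2-aminopropyl on a nitrogen on an aromatic ring.

Within the data shown here, no measured pair shows this change, so its effect in this assay is unknown. The step is expected to stay within the scatter, with a slight lean toward a higher number; the expected step is a 1.0-fold higher number from compound 3 to compound 4 (0.02 log units; within the scatter). Compound 4 is therefore estimated at 90000 nM, with a range from 35000 nM to 200000 nM.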

Compound 4, half-maximal cytotoxic concentration: 86000 nM
Compound 4: the middle estimate sits 1.0-fold (0.02 log units) above what was measured; the measured number falls inside the stated range.
By their numbers in this assay, from the lowest: compound 2; then compounds 1, 3 and 4 (each within the scatter of the next).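

In this assay the series gains its first step that changes one place only (no change at the digits printed from compound 3 to compound 4 (within the scatter)). Replacing 2-aminopropyl with 3-(aminomethyl)oxetan-3-yl on a nitrogen on an aromatic ring thus adds a four-membered non-aromatic ring and a hydrogen-bond acceptor without a step beyond the scatter in this pair. No supporting measurement bears on why the number holds.

Going by these compounds, whether the same exchange behaves alike on the cores of compound 1 or compound 2 remains open. Also open, on these data alone, is how a carboxylic acid or a longer chain would read on this nitrogen.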